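Chloro position on the anilino ring in a purine series

A few compounds are considered here, and "the series" means these few. Any claim that something is new, unique, unknown or untested is made for them only; others in the source may bear on it.

Compound 1 `CC(C)CCn1cnc2c(Nc3ccc(Cl)cc3)nc(N[C@H]3CC[C@H](N)CC3)nc21` carries a 4-chlorophenyl on the anilino nitrogen and an isopentyl chain on the core. In a functional assay on HCC827 cells (Homo sapiens) for inhibition, read by fluorescence, with a stated time of 72 h (on this read-out lower numbers stand for stronger inhibition of growth and higher numbers for weaker inhibition of growth), compound 1 gives 10200 nM. Compound 2 `CC(C)CCn1cnc2c(Nc3cccc(Cl)c3)nc(N[C@H]3CC[C@H](N)CC3)nc21` differs from it only by 3-chlorophenyl in place of 4-chlorophenyl on a nitrogen on an aromatic ring; in this assay compound 2 gives 10300 nM, and the step of a 1.0-fold higher number from compound 1 to compound 2 (0.00 log units; within the scatter) shows that swapping the chloro position on the anilino ring left the read-out essentially unchanged. Compound 3 `CCCCn1cnc2c(Nc3ccc(Cl)cc3)nc(N[C@H]3CC[C@H](N)CC3)nc21` keeps the 4-chlorophenyl of compound 1 but its core differs by hydrogen in place of methyl on a saturated chain carbon bound to two saturated chain carbons; in this assay compound 3 gives 10800 nM, with the step of a 1.1-fold higher number from compound 1 to compound 3 (0.02 log units; within the scatter) also inside the usual scatter. All three measured compounds therefore sit at about the same level, and none can be singled out as more or less potent than the others.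

Compound 4 `CCCCn1cnc2c(Nc3cccc(Cl)c3)nc(N[C@H]3CC[C@H](N)CC3)nc21` is not yet measured. It stands to compound 3 as compound 2 stands to compound 1: the change is 3-chlorophenyl in place of 4-chlorophenyl on a nitrogen on an aromatic ring, made at a place described in the same words for both pairs, on a core that differs from that of compound 1 by hydrogen in place of methyl on a saturated chain carbon bound to two saturated chain carbons. Among the compounds with values here, the only precedent for this change is the pair compound 1 to compound 2, where the number hardly moved. The step from compound 3 to compound 4 is therefore expected to be about a 1.0-fold higher number from compound 3 to compound 4 (0.01 log units; within the scatter), resting on the flat step a 1.0-fold higher number from compound 1 to compound 2 (0.00 log units; within the scatter). Compound 4 is estimated at 11000 nM in this assay, with a likely range from 6000 nM to 20000 nM.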

Compound 4, concentration for 50% growth inhibition: 7200 nM
Beside the measured number, compound 4's estimate is 1.5-fold (0.18 log units) above it; low and high end bracket the measured number.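

In this assay, within the data shown here, 3-chlorophenyl in place of 4-chlorophenyl on the core of compound 3 gives a 1.5-fold lower number from compound 3 to compound 4 (0.18 log units; within the scatter), and this step does not differ from the one for the same change on the core of compound 1: the same change on two cores in this assay, a 1.0-fold higher number (0.00 log units; within the scatter) from compound 1 to compound 2 and a 1.5-fold lower number (0.18 log units; within the scatter) from compound 3 to compound 4, 1.5-fold (0.18 log units) apart, within the scatter of two such steps. The chain change, read on the 3-chlorophenyl pair, gives a 1.4-fold lower number from compound 2 to compound 4 (0.16 log units; within the scatter), and it likewise agrees with its earlier counterpart on the 4-chlorophenyl pair: the same change on two cores in this assay, a 1.1-fold higher number (0.02 log units; within the scatter) from compound 1 to compound 3 and a 1.4-fold lower number (0.16 log units; within the scatter) from compound 2 to compound 4, 1.5-fold (0.18 log units) apart, within the scatter of two such steps. Both changes therefore carry from one core to the other without a detectable difference, but every step here lies within the scatter, so this agreement rests on small steps across four compounds and two chains and does not show that either change would remain as small on other cores, nor does it exclude a small real effect.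

Still open, as far as these compounds go, is whether a nitrile or a methoxy group in place of the chloro on the phenyl ring, or a longer chain such as hexyl on the core, would move the growth-inhibition read-out beyond the scatter. Also open is how a carboxylic acid in place of the amine would behave, since all four compounds shown carry that amine unchanged.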